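Chloro step repeated on a second core

The source may hold more compounds than are shown below. What is called first, only, known or untested is meant among the compounds shown, and "the series" means these compounds.

Compound 1 `CN(C)CCCNc1nc(-c2ccc(NC(=O)Nc3ccccc3Cl)cc2)nc2ccsc12` is the reference. In a functional assay on MKN-45 cells (Homo sapiens) for cytotoxicity, read by MTT assay, with a stated time of 72 h (on this read-out lower numbers stand for stronger inhibition and higher numbers for weaker inhibition), compound 1 gives 690 nM. Among the compounds with values here, compound 2 `CN(C)CCCNc1nc(-c2ccc(NC(=O)Nc3ccc(Cl)cc3Cl)cc2)nc2ccsc12` carries one further chloro, described as chloro in place of hydrogen on an aromatic carbon; in this assay compound 2 gives 2270 nM, and the step of a 3.3-fold higher number from compound 1 to compound 2 (0.52 log units; beyond the scatter) is the only measured instance of this change. Compound 3 `CN(C)CCCNc1nc(-c2ccc(NC(=O)Nc3ccccc3Cl)cc2)nc2c(Cl)c(Cl)sc12` has a different core; the difference between the core of compound 1 and the core of compound 3 is not broken down here. In this assay compound 3 gives 1330 nM; its number lies within the scatter of both compound 1 and compound 2, so no order is claimed among those three beyond the step from compound 1 to compound 2.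

Compound 4 `CN(C)CCCNc1nc(-c2ccc(NC(=O)Nc3ccc(Cl)cc3Cl)cc2)nc2c(Cl)c(Cl)sc12` is not yet measured. It differs from compound 3 by chloro in place of hydrogen on an aromatic carbon, and the place of the change is the same, word for word, as in the step from compound 1 to compound 2, so this is the same change made on the core of compound 3. With one measured instance only, the expectation rests on it alone: for compound 4 a step of about the same size is expected, a 3.3-fold higher number from compound 3 to compound 4 (0.52 log units; beyond the scatter), because a 3.3-fold higher number from compound 1 to compound 2 (0.52 log units; beyond the scatter) was the outcome of this change on the core of compound 1. Compound 4 is accordingly estimated at 4400 nM in this assay, with the range 2000 nM to 9500 nM expected to cover most repeats. Within the data shown here, the range is wide because only the single step of a 3.3-fold higher number from compound 1 to compound 2 (0.52 log units; beyond the scatter) supports the transfer; whether the core of compound 3 carries the change alike is untested.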

Compound 4, half-maximal inhibitory concentration: 2560 nM
Estimate against measurement, compound 4: 1.7-fold (0.24 log units) above; the range from low to high includes it.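

Carrying the change from 2-chlorophenyl to 2,4-dichlorophenyl onto the core of compound 3 gives, in this assay, a 1.9-fold higher number from compound 3 to compound 4 (0.28 log units; within the scatter). Set beside the step on the core of compound 1, this second instance gives no ground to say that the two cores handle the change differently: the same change on two cores in this assay, a 3.3-fold higher number (0.52 log units; beyond the scatter) from compound 1 to compound 2 and a 1.9-fold higher number (0.28 log units; within the scatter) from compound 3 to compound 4, 1.7-fold (0.23 log units) apart, within the scatter of two such steps The two steps are compatible with one shared effect of the added chloro, but they do not establish one, since only the first lies beyond the scatter, the second alone would not separate compound 4 from compound 3, and two cores are too few to support a rule for the series.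

Still open, going by these compounds, is whether the cost seen on the core of compound 1 belongs to chloro itself or would also appear with fluoro, methyl, methoxy or trifluoromethyl on the same carbon of the ring. The compounds shown also leave open whether the steps would hold up with a morpholine or a longer chain in place of the dimethylaminopropyl side chain that all of them carry.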